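The compounds below may be only part of what the source reports. "The series", "measured", "known", "first", "only" and "open" are said of these compounds alone.

Measured compounds in this series:
- compound 2 `COc1ccc(CNCCCNS(=O)(=O)c2cc(C(F)(F)F)cc(C(F)(F)F)c2)cc1OC`: 6400 nM
- compound 1 `O=S(=O)(NCCCCNCc1ccc(Br)cc1)c1cc(C(F)(F)F)cc(C(F)(F)F)c1`: 2900 nM
- compound 3 `O=S(=O)(NCCCNCc1ccc(C(F)(F)F)cc1)c1cc(C(F)(F)F)cc(C(F)(F)F)c1`: 2000 nM

In a functional assay on ASPC1 cells (Homo sapiens) for inhibition, read by MTT assay, with a stated time of 72 h (on this read-out lower numbers stand for stronger inhibition of growth and higher numbers for weaker inhibition of growth), compound 2 gives the highest number of the three; compound 1 gives 2900 nM and compound 3 gives 2000 nM, both beyond the scatter from it. Compound 4 `O=S(=O)(NCCCNCc1cccc2ccccc12)c1cc(C(F)(F)F)cc(C(F)(F)F)c1` differs from compound 2 by naphthalen-1-yl in place of 3,4-dimethoxyphenyl on a saturated chain carbon bound to an amine nitrogen. Going by the values given here, one measured step bears on this change at the same place: a 3.2-fold lower number from compound 2 to compound 3 (0.51 log units; beyond the scatter). Among the compounds with values here, no step is available for compound 1 against compound 2. Within the data shown here, the only precedent moves downward when the 3,4-dimethoxyphenyl is replaced, so a modest downward step is expected for compound 4 in this assay as well, a 2.6-fold lower number from compound 2 to compound 4 (0.41 log units; beyond the scatter). Compound 4 is estimated at 2500 nM, range 1000 nM to 6000 nM.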

Compound 4, concentration for 50% growth inhibition: 21000 nM
Compound 4: the middle estimate sits 8.4-fold (0.92 log units) below what was measured; the whole stated range lies below it.
By their numbers in this assay, from the lowest: compounds 3 and 1 (each within the scatter of the next); then compound 2; then compound 4.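

In this assay, replacing 3,4-dimethoxyphenyl on a saturated chain carbon bound to an amine nitrogen does not always lower the number: naphthalen-1-yl gives a 3.3-fold higher number from compound 2 to compound 4 (0.52 log units; beyond the scatter) and so runs opposite to the precedent at this place. Against 4-(trifluoromethyl)phenyl, the same group gives an 11-fold higher number from compound 3 to compound 4 (1.02 log units; beyond the scatter) as the largest step yet seen at this position.

Going by these compounds, whether naphthalen-2-yl or a plain phenyl would follow compound 3 or compound 4 stays open. No measurement shown here accounts for the higher number of compound 4.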